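Cyclopropyl amide series: chloro to methoxy on the aryl ring

This account rests on a few compounds, and the source may have more. Where it says the series, first, only, none or still open, it means among the compounds named here.

Measured compounds:
compound 1 `CC(C)C[C@H](N)CN(C(=O)C(C)Cc1ccccc1)c1ccc(-c2ccccc2)cc1` — 1.2 nM
compound 2 `CC[C@H](C)[C@H](N)CN(C(=O)[C@@H]1C[C@H]1c1cccc(Cl)c1)c1ccc(-c2ccccc2)cc1` — 2200 nM

In a functional assay for agonist activity at G protein-coupled receptor 88 (Homo sapiens), read by HTRF and cAMP accumulation (a higher number here means that more compound is needed for the effect, a lower number that less compound is needed), compound 1 gives 1.2 nM. Going by the values given here, compound 2 gives 2200 nM in this assay, the higher of the two numbers; its only neighbour is compound 1, and the gap between them lies far beyond the scatter, though the two differ in more than one place, so no single change can be read from that pair.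

Compound 3 `CC[C@H](C)[C@H](N)CN(C(=O)[C@@H]1C[C@H]1c1cccc(OC)c1)c1ccc(-c2ccccc2)cc1` departs from compound 2 in one place: methoxy in place of chloro on an aromatic carbon. Methoxy brings one acceptor where chloro had none. Among the compounds with values here, no measured pair isolates this change, so its size and direction can only be guessed. The step from compound 2 to compound 3 is expected to be a 1.4-fold higher number from compound 2 to compound 3 (0.13 log units; within the scatter), a modest shift without a confident direction. Compound 3 is estimated at 3000 nM, with a range from 700 nM to 12000 nM.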

Compound 3, half-maximal effective concentration: 3000 nM
Beside the measured number, compound 3's estimate shows no gap at the digits printed; the range from low to high includes it.
By their numbers in this assay, from the lowest: compound 1; then compounds 2 and 3 (each within the scatter of the next).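

In this assay, going by these compounds alone, methoxy in place of chloro on an aromatic carbon, meta to a large group, gives a 1.4-fold higher number from compound 2 to compound 3 (0.13 log units; within the scatter); this is the first pair that differs in one place, and at this position the two groups cannot be told apart. The hydrogen-bond acceptor that methoxy brings and chloro lacks leaves no readable mark on the number here. No measurement at hand speaks to why the two groups read alike.

From the compounds shown here alone, whether a different group on this aromatic carbon, such as an amine, a carboxylic acid or a nitrile, would move the number beyond the scatter remains open. Also open is which of the several differences between compound 1 and compound 2 accounts for the gap between them.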